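Removing a Fluorine: What to Expect for Cell Inhibition

This account rests on a few compounds, and the source may have more. Where it says the series, first, only, none or still open, it means among the compounds named here.

Of the compounds shown here, three built on a shared core have been tested in a functional assay on A549 cells (Homo sapiens) for inhibition; a lower number here means a stronger inhibitor, a higher number a weaker inhibitor. Compound 1 `CCOC(=O)CNC(=O)N1CC1C#N` gives 24000 nM. Compound 3 `CC(C)(C)NC(=O)N1CC1C#N` gives 180000 nM. Compound 2 `N#CC1CN1C(=O)Nc1ccc(F)cc1` gives 6200 nM, the lowest of the three numbers; its gap to compound 1 and its larger gap to compound 3 both lie beyond the usual scatter of repeated measurements, so on these numbers compound 2 is the strongest inhibitor of the set.

The next compound, compound 4 `N#CC1CN1C(=O)Nc1ccccc1`, differs from compound 2 in one place: hydrogen in place of fluoro on an aromatic carbon. Among the measured compounds shown here, no pair of measured compounds shows this particular change, so there is no measured step to lean on. A single small group leaving from an aromatic carbon is the kind of change that often moves a result only a little, and nothing among the three measured compounds points to a large shift in either direction. The expected step is therefore a 1.5-fold higher number from compound 2 to compound 4 (0.16 log units; within the scatter), meaning little change, with a modest drift toward a weaker inhibitor more likely than a gain. Compound 4 is estimated to give 9000 nM in this assay, with a likely range from 3000 nM to 30000 nM.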

Compound 4, half-maximal inhibitory concentration: 9000 nM
The estimate for compound 4 equals the measured number at the digits printed; low and high end bracket the measured number.
By their numbers in this assay, from the lowest: compounds 2 and 4 (each within the scatter of the next); then compound 1; then compound 3.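

In this assay, putting hydrogen in place of fluoro on an aromatic carbon, para to a group of 8 heavy atoms, gives a 1.5-fold higher number from compound 2 to compound 4 (0.16 log units; within the scatter) and so leaves the result inside the normal spread of repeat measurements. Among the compounds shown here, this is the first direct test of this position, and it shows that the fluoro is not needed to keep the inhibition seen in compound 2, since on these numbers compound 2 and compound 4 cannot be told apart. No supporting data are available to explain this result.

For the compounds shown here, the single swap tests only fluoro against hydrogen, so it remains open whether a larger or quite different group on the same carbon, such as a methoxy group, an amine or a carboxylic acid, would shift the number more clearly in either direction. From the compounds shown here alone, it also remains open whether the same swap would prove just as quiet on the other carbons of the six-membered aromatic ring, where a fluoro might matter more or less than it does here.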